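The source may hold more compounds than are shown below. What is called first, only, known or untested is meant among the compounds shown, and "the series" means these compounds.

Measured compounds:
- compound 1 `COc1cc2c(Oc3ccc(NC(=O)N/N=C/c4ccc(F)cc4Cl)cc3F)ccnc2cc1OCCCN1CCCCC1`: in a functional assay on A549 cells (Homo sapiens) for cytotoxicity, read by MTT assay, with a stated time of 72 h (a lower number here means a stronger inhibitor, a higher number a weaker inhibitor), compound 1 gives 130 nM
- compound 2 `COc1cc2c(Oc3ccc(NC(=O)N/N=C/c4ccc(C(F)(F)F)cc4)cc3F)ccnc2cc1OCCCN1CCC(C)CC1`: in this assay compound 2 gives 650 nM
- compound 3 `COc1cc2c(Oc3ccc(/C=N/NC(=O)Nc4ccc(F)c(F)c4)cc3F)ccnc2cc1OCCCN1CCCCC1`: in this assay compound 3 gives "not determined" (no result reported)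

Compound 3 stands without a number; nothing in the shown data tells where it sits on the scale set by compound 1 and compound 2. Those two differ in more than one place, so only their two values can be stated, not a single step.

Compound 4 `COc1cc2c(Oc3ccc(/C=N/NC(=O)Nc4ccc(F)cc4Br)cc3F)ccnc2cc1OCCCN1CCCCC1` is the next entry, not yet measured. Its difference from compound 3 is 2-bromo-4-fluorophenyl in place of 3,4-difluorophenyl on an amide-type nitrogen. Within the data shown here, there is no measured pair that isolates such a change on the amide-type nitrogen, and the missing value for compound 3 leaves no anchor for a step. Any expectation therefore rests on the range set by compound 1 and compound 2 alone, and the size or direction of a step from compound 3 cannot be stated beyond the scatter.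

Compound 4 is expected to fall near 300 nM in this assay, within an estimated range from 60 nM to 2000 nM.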

Compound 4, half-maximal inhibitory concentration: 98 nM
Compound 4: middle estimate off by 3.1-fold (0.49 log units), on the high side; measured number inside the range.
By their numbers in this assay, from the lowest: compounds 4 and 1 (each within the scatter of the next); then compound 2.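

No step can be read between compound 3, which has no number, and compound 4 at 98 nM in this assay. No measured evidence bears on this result. The compounds shown leave open how 2-bromo-4-fluorophenyl compares with 3,4-difluorophenyl on the amide-type nitrogen.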